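Closing a diol into an epoxide on the side chain

The source may report more compounds than this note shows. Statements on the series, on what has been measured and on what is new or still open speak of the compounds shown alone.

Compound 2 (`C=C[C@@](C)(/C=C/c1ccc(O)cc1)CC[C@@H](O)C(C)(C)O`) stands at the edge of what a functional assay on A549 cells (Homo sapiens) for cytotoxicity, read by MTT assay, with a stated time of 48 h (a higher number here means a weaker inhibitor, a lower number a stronger inhibitor), can report. In this assay compound 2 gives > 10000 nM, which is a limit of the assay and not a number. Compound 1 (`C=C[C@@](C)(/C=C/c1ccc(O)cc1)CCC(=O)C(=C)C`) likewise sits at a limit, for in this assay compound 1 gives > 10000 nM. The step that the two limits leave unreadable from compound 1 to compound 2 cannot be read, since (the limit of > 10000 nM in this assay, at which 2 of the 2 values shown sit). Compound 3 (`C=C[C@@](C)(/C=C/c1ccc(O)cc1)CCC1OC1(C)C`) differs from compound 2 by 3,3-dimethyloxiran-2-yl in place of 1,2-dihydroxy-2-methylpropyl on a saturated chain carbon, three bonds along the chain from two double-bonded chain carbons. Within the data shown here, no measured step with a readable size bears on this change; the single neighbouring step is the unreadable one. The account therefore expects no shift beyond the scatter in either direction, and the expected step is a step that the limit leaves unreadable from compound 2 to compound 3, with compound 3 most likely staying at the limit. Compound 3 is estimated at 15000 nM, in a range from 4000 nM to 60000 nM.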

Compound 3, half-maximal inhibitory concentration: > 10000 nM
Compound 3: a limit, no number (the forecaster's own chance of this, stated with the estimate: 75%); the middle value is on the limit's open side.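

Among these compounds, compound 1, compound 2 and compound 3 all sit at a limit of this assay, not at a number, so no step among them can be read: the limit of > 10000 nM in this assay, at which 3 of the 3 values shown sit. The compounds shown leave open whether (1-methylethenyl)carbonyl, 1,2-dihydroxy-2-methylpropyl and 3,3-dimethyloxiran-2-yl differ at all in this assay.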